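A few compounds are considered here, and "the series" means these few. Any claim that something is new, unique, unknown or untested is made for them only; others in the source may bear on it.

Measured in a functional assay on A549 cells (Homo sapiens) for antiproliferative activity, read by MTT assay, with a stated time of 72 h; on this read-out lower numbers stand for stronger inhibition and higher numbers for weaker inhibition:
- compound 1 `COc1ccccc1-c1ccc2ncn(-c3cc(OC)c(OC)c(OC)c3)c2c1`: 4320 nM
- compound 2 `COc1cc(-n2cnc3ccc(-c4ccc(C)cc4F)cc32)cc(OC)c1OC`: > 10000 nM, a limit of the assay
- compound 3 `COc1cc(-n2cnc3ccc(-c4cc(F)ccc4F)cc32)cc(OC)c1OC`: 7940 nM

Compound 3 lies within the scatter of compound 1, with a 1.8-fold higher number from compound 1 to compound 3 (0.26 log units; within the scatter). Compound 4 `COc1cc(-n2cnc3ccc(-c4ccc([N+](=O)[O-])cc4)cc32)cc(OC)c1OC` carries 4-nitrophenyl in place of 2,5-difluorophenyl on an aromatic carbon.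

Among the measured compounds shown here, no measured compound has the 4-nitrophenyl group, so only swaps of the aryl group at this same place can guide the expectation. These were small, with an at least 2.3-fold higher number from compound 1 to compound 2 (0.36 log units; beyond the scatter) and an at least 1.2-fold lower number from compound 2 to compound 3 (0.10 log units; that floor lies within the scatter). A step beyond the scatter is therefore not expected, though reaching the limit remains possible. The expected change is a 1.1-fold lower number from compound 3 to compound 4 (0.05 log units; within the scatter). Compound 4 is estimated at 7000 nM, within a range of 2000 nM to 15000 nM.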

Compound 4, half-maximal inhibitory concentration: 8940 nM
Compound 4: the middle estimate sits 1.3-fold (0.11 log units) below what was measured; measured number inside the range.
By their numbers in this assay, from the lowest: compounds 1, 3 and 4 (each within the scatter of the next, the first and the last beyond it). At a limit, above all of these: compound 2.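

In this assay, replacing 2,5-difluorophenyl with 4-nitrophenyl, which brings in hydrogen-bond acceptors, leaves the result within the scatter, with a 1.1-fold higher number from compound 3 to compound 4 (0.05 log units; within the scatter). Among the compounds shown here, measured against the 2-methoxyphenyl group, the new group gives the first step beyond the scatter between two real numbers, with a 2.1-fold higher number from compound 1 to compound 4 (0.32 log units; beyond the scatter). Compound 2 gives only a limit, so its comparison sets no more than a floor, with an at least 1.1-fold lower number from compound 2 to compound 4 (0.04 log units; that floor lies within the scatter): the limit of > 10000 nM in this assay, at which 1 of the 4 values shown sits.

All the groups shown are substituted phenyl rings. Going by these compounds, how an amine or a carboxylic acid at this place would read remains open.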